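The source may hold more compounds than are shown below. What is called first, only, known or untested is meant among the compounds shown, and "the series" means these compounds.

Measured so far:
compound 1 `Cc1ccccc1-n1cc(COc2cccc(NC(=O)Nc3ccc(Cl)c(C(F)(F)F)c3)c2)nn1` — 3440 nM
compound 2 `O=C(Nc1cccc(OCc2cn(-c3ccc(F)cc3)nn2)c1)Nc1ccc(Cl)c(C(F)(F)F)c1` — 1350 nM
compound 3 `O=C(Nc1cccc(OCc2cn(-c3ccccc3Br)nn2)c1)Nc1ccc(Cl)c(C(F)(F)F)c1` — 2810 nM

All three compounds share the same core and differ only in the ring that sits on an aromatic nitrogen. In a functional assay on HepG2 cells (Homo sapiens) for inhibition, read by MTT assay, with a stated time of 72 h (on this read-out lower numbers stand for stronger inhibition and higher numbers for weaker inhibition), compound 1 gives the highest number of the three; compound 3 lies nearest to it and compound 2 furthest from it.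

Compound 4 `O=C(Nc1cccc(OCc2cn(-c3cccc(I)c3)nn2)c1)Nc1ccc(Cl)c(C(F)(F)F)c1` has not yet been measured. Set against compound 1, its structure shows (3-iodophenyl in place of 2-methylphenyl on an aromatic nitrogen).

Three measured steps speak to this change. a 2.5-fold lower number from compound 1 to compound 2 (0.41 log units; beyond the scatter). a 1.2-fold lower number from compound 1 to compound 3 (0.09 log units; within the scatter). a 2.1-fold higher number from compound 2 to compound 3 (0.32 log units; beyond the scatter). Taken together, exchanging the methyl for a halogen gave a small shift, while the 4-fluorophenyl brought a modest lowering. Among the measured compounds shown here, no measured pair shows a 3-iodophenyl, so the effect of iodine in that place is not covered by the data, and compound 4 sits between the two cases seen.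

For compound 4 the expected step is a 1.6-fold lower number from compound 1 to compound 4 (0.19 log units; within the scatter), a modest lowering that may not clear the scatter. Compound 4 is therefore estimated at 2200 nM, with a range from 900 nM to 5500 nM.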

Compound 4, half-maximal inhibitory concentration: 4780 nM
For compound 4 the middle estimate is 2.2-fold (0.34 log units) below the measured one, and the stated range covers the measured number.
By their numbers in this assay, from the lowest: compound 2; then compounds 3, 1 and 4 (each within the scatter of the next).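

In this assay, the 3-iodophenyl does not share the lower number seen with the 4-fluorophenyl, as shown by a 3.5-fold higher number from compound 2 to compound 4 (0.55 log units; beyond the scatter), so carrying a halogen on this ring is not enough by itself to give that lower number: compound 2 fits such a pattern, while compounds 3 and 4 go against it. The other two steps, a 1.4-fold higher number from compound 1 to compound 4 (0.14 log units; within the scatter) and a 1.7-fold higher number from compound 3 to compound 4 (0.23 log units; within the scatter), leave the 3-iodophenyl indistinguishable from the 2-methylphenyl and the 2-bromophenyl, and compound 2 now stands apart from all three other compounds with the lowest number. Nothing available explains these differences.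

The halogen and its place on the ring change together across compounds 2, 3 and 4, so these numbers cannot show whether the atom itself or its place matters more. Also open, from the compounds shown here alone, is how this assay would read with an amine or a carboxylic acid on the ring in this same place.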